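This account rests on a few compounds, and the source may have more. Where it says the series, first, only, none or still open, it means among the compounds named here.

Measured in a functional assay on HL-60 cells (Homo sapiens) for antiproliferative activity, read by MTT assay, with a stated time of 24 h; on this read-out lower numbers stand for stronger inhibition and higher numbers for weaker inhibition:
- compound 1 `CCCCc1oc2ccccc2c1C(=O)c1ccc(OCC(N)=O)cc1`: > 50000 nM, a limit
- compound 2 `CCCCc1oc2ccccc2c1C(=O)c1ccc(OCC(=O)Nc2cccc(OC)c2)cc1`: > 50000 nM, a limit
- compound 3 `CCCCc1oc2ccccc2c1C(=O)c1ccc(OCC(=O)NCc2ccccc2)cc1`: > 50000 nM, a limit

Compound 3 is known only as a limit, > 50000 nM. Compound 4 `CCCCc1oc2ccccc2c1C(=O)c1ccc(OCCCC(=O)N2CCOCC2)cc1` carries 2-((morpholin-4-yl)carbonyl)ethyl in place of benzylcarbamoyl on a saturated chain carbon bound to an oxygen on an aromatic ring.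

The measured steps bearing on this change are a step that the two limits leave unreadable from compound 1 to compound 2 and a step that the two limits leave unreadable from compound 2 to compound 3, and neither can be sized. Given a step that the two limits leave unreadable from compound 1 to compound 3 and (the limit of > 50000 nM in this assay, at which 3 of the 3 values shown sit), no step beyond the scatter is expected in this assay, and no direction can be expected.

The expected step is a number no higher from compound 3 to compound 4 (the limit leaves the size open). For compound 4 the estimated value is 50000 nM, with an expected range of 15000 nM to 100000 nM.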

Compound 4, half-maximal inhibitory concentration: 34100 nM
The estimate for compound 4 lay 1.5-fold (0.17 log units) above the measured number; low and high end bracket the measured number.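

In this assay compound 4, alone among the compounds shown, gives a number rather than a limit: the limit of > 50000 nM in this assay, at which 3 of the 4 values shown sit. The change to 3-((morpholin-4-yl)carbonyl)propyl gives an at least 1.4-fold lower number from compound 3 to compound 4 (0.16 log units; that floor lies within the scatter), an at least 1.4-fold lower number from compound 2 to compound 4 (0.16 log units; that floor lies within the scatter) and an at least 1.4-fold lower number from compound 1 to compound 4 (0.16 log units; that floor lies within the scatter), each with its floor within the scatter, while the steps among the other compounds cannot be read.

From the compounds shown here alone, the morpholin-4-yl group and the longer chain change together in compound 4, and which of them carries the step stays open. Going by these compounds, how a carboxylic acid or an amine at the end of that chain would read also stays open.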